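Swapping the Aryl Group on a Weak Cytotoxic Scaffold

This account rests on a few compounds, and the source may have more. Where it says the series, first, only, none or still open, it means among the compounds named here.

Compound 1 `FC(F)(F)Oc1ccc(-c2cc(COc3ccccc3-c3nc4ccccc4s3)on2)cc1` was tested in a functional assay on MCF7 cells (Homo sapiens) for cytotoxicity, read by MTT assay, with a stated time of 24 h (a higher number here means a weaker inhibitor, a lower number a stronger inhibitor), where compound 1 gives 26600 nM. For the measured compounds named here, of the two numbers known so far, this is the highest. The other measured compound, compound 2 `FC(F)(F)c1cccc(-n2cc(COc3ccccc3-c3nc4ccccc4s3)nn2)c1`, gives 18900 nM in this assay; the two values lie within the scatter of each other, so no real difference between them is shown. Going by the values given here, compound 2 also differs from compound 1 in more than one place, so no single step connects the pair.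

Compound 3 `Fc1ccccc1-c1cc(COc2ccccc2-c2nc3ccccc3s2)on1` has not yet been measured. It differs from compound 1 in one place: 2-fluorophenyl in place of 4-(trifluoromethoxy)phenyl on an aromatic carbon. Among the compounds with values here, no measured pair shows a change of this kind, so there is no direct guide to its size. Because compound 1 gives 26600 nM, a weak result, compound 3 is expected to stay in a similarly weak range, and the step of a 1.1-fold lower number from compound 1 to compound 3 (0.03 log units; within the scatter) is expected to be no larger than the scatter, in no fixed direction. Compound 3 is therefore estimated to give 25000 nM in this assay, somewhere between 8000 nM and 80000 nM.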

Compound 3, half-maximal inhibitory concentration: 23900 nM
Compound 3: middle estimate off by 1.0-fold (0.02 log units), on the high side; the range from low to high includes it.
By their numbers in this assay, from the lowest: compounds 2, 3 and 1 (each within the scatter of the next).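

In this assay, placing 2-fluorophenyl instead of 4-(trifluoromethoxy)phenyl on the aromatic carbon next to the ring nitrogen gives a 1.1-fold lower number from compound 1 to compound 3 (0.05 log units; within the scatter). For the compounds shown here, this is the first step that can be read at this position, and it shows that this exchange, which removes heavy atoms and a hydrogen-bond acceptor from the group, leaves the result within the scatter and still in the weak range. Nothing measured here accounts for how close the two values lie.

Both groups compared at this position are phenyl rings carrying fluorine, so a single step says little about the position as a whole. As far as these compounds go, whether an amine, a carboxylic acid or a longer chain placed here would move the number beyond the scatter remains open.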